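This account rests on a few compounds, and the source may have more. Where it says the series, first, only, none or still open, it means among the compounds named here.

Notes on the series. Compound 1 `CNC(=O)c1ccncc1Nc1cc(-c2ccc3ccn(C)c3c2)c2nccnc2c1` is the reference with methyl on the amide-type nitrogen; in an assay on lysate for inhibition of 6-phosphofructo-2-kinase/fructose-2,6-bisphosphatase 3 (Homo sapiens), with stated times of 0.5 min and 45 min (a lower number here means a stronger inhibitor, a higher number a weaker inhibitor), compound 1 gives 7020 nM. Compound 2 `CN1CCC(NC(=O)c2ccncc2Nc2cc(-c3ccc4ccn(C)c4c3)c3nccnc3c2)CC1=O` gives 48800 nM, and compound 3 `CC(=O)N1CCCC(NC(=O)c2ccncc2Nc2cc(-c3ccc4ccn(C)c4c3)c3nccnc3c2)C1` gives 13500 nM, the second highest of the three numbers and close to compound 1. Among the compounds with values here, the steps so far: a 7.0-fold higher number from compound 1 to compound 2 (0.84 log units; beyond the scatter); a 1.9-fold higher number from compound 1 to compound 3 (0.28 log units; within the scatter); a 3.6-fold lower number from compound 2 to compound 3 (0.56 log units; beyond the scatter). Compound 4 `CC(=O)N1CCOC(CNC(=O)c2ccncc2Nc2cc(-c3ccc4ccn(C)c4c3)c3nccnc3c2)C1` changes the same position again: (4-acetylmorpholin-2-yl)methyl in place of 1-acetylpiperidin-3-yl on an amide-type nitrogen. The two ring variants at this nitrogen moved the number only modestly, and the step from compound 1 to compound 3 stayed within the scatter, so for compound 4 a step of a 1.1-fold higher number from compound 3 to compound 4 (0.05 log units; within the scatter) is expected, essentially none beyond the scatter. Compound 4 is therefore estimated at 15000 nM, with a range of 6000 nM to 40000 nM.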

Compound 4, half-maximal inhibitory concentration: > 100000 nM
Compound 4 ended at the assay's limit; the forecaster's own chance of this, stated with the estimate: 10%; middle value at least 6.6-fold (0.82 log units) from the limit.
By their numbers in this assay, from the lowest: compounds 1 and 3 (each within the scatter of the next); then compound 2. At a limit, above all of these: compound 4.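

In this assay compound 4 stands at a limit and not at a number: the limit of > 100000 nM in this assay, at which 1 of the 4 values shown sits. This position is less forgiving than the first three compounds suggested, with an at least 7.4-fold higher number from compound 3 to compound 4 (0.86 log units; beyond the scatter), alongside an at least 2.0-fold higher number from compound 2 to compound 4 (0.31 log units; beyond the scatter) and an at least 14-fold higher number from compound 1 to compound 4 (1.15 log units; beyond the scatter). The acetylated six-membered non-aromatic ring is present on both sides of the first step, so keeping that ring does not by itself preserve the read-out.

As far as these compounds go, the ring oxygen and the added chain carbon enter together, so their separate contributions remain open. A (1-acetylpiperidin-3-yl)methyl group would separate them, and a free ring amine would test the acetyl group.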